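A few compounds are considered here, and "the series" means these few. Any claim that something is new, unique, unknown or untested is made for them only; others in the source may bear on it.

Among the measured compounds shown here, compound 1 `NC(=O)CN(Cc1ccc(Cl)cc1)Cc1ccc([N+](=O)[O-])s1` is the first of the pair with a number, and in a functional assay on HEK293 cells for agonist activity at nuclear receptor subfamily 1 group D member 1 (Homo sapiens), read by a luciferase reporter, with a stated time of 24 h (a higher number here means that more compound is needed for the effect, a lower number that less compound is needed), compound 1 gives 3000 nM. Compound 2 `CC(C)(C)OC(=O)N1CCC(CN(Cc2ccc(Cl)cc2)Cc2ccc([N+](=O)[O-])s2)C1` shares the same core but carries a different group on the central nitrogen, and in this assay compound 2 gives 1800 nM. These two numbers lie within the usual scatter of each other, so neither compound can be said to need less material than the other; compound 2 simply holds the lower of the two figures. Compound 3 `CC(C)(C)OC(=O)N1CCCC(CN(Cc2ccc(Cl)cc2)Cc2ccc([N+](=O)[O-])s2)C1` belongs to the same set, but in this assay compound 3 gives "not determined" (no result reported), so no result was reported for it.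

Compound 4 `O=C(Nc1ccc([N+](=O)[O-])cc1)N1CCC(CN(Cc2ccc(Cl)cc2)Cc2ccc([N+](=O)[O-])s2)C1` keeps everything in compound 2 except one end of the ring substituent: (4-nitrophenyl)amino in place of tert-butoxy on a carbonyl carbon. For the measured compounds named here, no pair of measured compounds shows a change of this kind, so there is no measured step to lean on. A modest shift toward a lower number, only a little beyond the scatter, is expected, a 1.5-fold lower number from compound 2 to compound 4 (0.18 log units; within the scatter). Compound 4 is therefore estimated at 1200 nM, with a plausible range from 300 nM to 5000 nM.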

Compound 4, half-maximal effective concentration: 400 nM
For compound 4 the middle estimate is 3.0-fold (0.48 log units) above the measured one; the range from low to high includes it.
By their numbers in this assay, from the lowest: compound 4; then compounds 2 and 1 (each within the scatter of the next).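

Compound 2 and compound 1 differ in more than one place, so the earlier numbers said nothing about this end of the ring substituent. In this assay, (4-nitrophenyl)amino in place of tert-butoxy on a carbonyl carbon gives a 4.5-fold lower number from compound 2 to compound 4 (0.65 log units; beyond the scatter), so the group at this position does matter, and the larger group with its six-membered aromatic ring is accepted here. No measurement shown here explains why the number falls.

The compounds shown leave open which part of the entering group goes with the lower number: the aromatic ring, the nitro group or the hydrogen on the amino nitrogen. A plain phenylamino group or a methylamino group on the same carbonyl carbon would help to separate these parts.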